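The source may hold more compounds than are shown below. What is called first, only, known or untested is meant among the compounds shown, and "the series" means these compounds.

Compound 1 `COc1ccc(-n2nc(-c3ccc4ccccc4c3)nc2N2C(=O)COC23C=CC(=O)C=C3)cc1` gives 60 nM 
Compound 2 `O=C1C=CC2(C=C1)OCC(=O)N2c1nc(-c2ccc3ncccc3c2)nn1-c1ccccc1` gives 50 nM 
Compound 3 `O=C1C=CC2(C=C1)OCC(=O)N2c1nc(-c2ccc(F)c3ccccc23)nn1-c1ccccc1` gives 80 nM 

All three compounds were tested in a functional assay on MDA-MB-231 cells (Homo sapiens) for antiproliferative activity, with a stated time of 5 days (on this read-out lower numbers stand for stronger inhibition and higher numbers for weaker inhibition), and their numbers lie close together. Compound 3 at 80 nM sits within the usual scatter of both compound 1 and compound 2, so these values cannot be put in a firm order.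

Compound 4 `O=C1C=CC2(C=C1)OCC(=O)N2c1nc(-c2ccc3ccccc3c2)nn1-c1ccccc1` has not yet been measured. It keeps the rest of compound 3 and changes one group naphthalen-2-yl in place of 4-fluoronaphthalen-1-yl on an aromatic carbon with naphthalen-2-yl in place of 4-fluoronaphthalen-1-yl on an aromatic carbon of a five-membered aromatic ring with 3 nitrogen.

For the measured compounds named here, one measured step bears directly on this place. It is a 1.6-fold higher number from compound 2 to compound 3 (0.20 log units; within the scatter) with 4-fluoronaphthalen-1-yl in place of quinolin-6-yl, and it stays within the scatter. Compound 4 also differs elsewhere from compound 1, which already carries naphthalen-2-yl and gives 60 nM in this assay as a further guide.

No step beyond the scatter is therefore expected in this assay for this exchange. The expected change is a 1.3-fold lower number from compound 3 to compound 4 (0.12 log units; within the scatter) and so stays small. For compound 4 the estimated value is 60 nM with an expected range from 30 nM to 120 nM in this assay.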

Compound 4, half-maximal inhibitory concentration: 70 nM
The estimate for compound 4 lay 1.2-fold (0.07 log units) below the measured number; low and high end bracket the measured number.
By their numbers in this assay, from the lowest: compounds 2, 1, 4 and 3 (each within the scatter of the next).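

In this assay, a 1.1-fold lower number from compound 3 to compound 4 (0.06 log units; within the scatter) shows that this aromatic carbon, between two ring nitrogen atoms, takes naphthalen-2-yl as well as 4-fluoronaphthalen-1-yl, with no step beyond the scatter, even though the fluorine is gone and the attachment point on the naphthalene differs. The comparison with quinolin-6-yl, a 1.4-fold higher number from compound 2 to compound 4 (0.15 log units; within the scatter), also stays within the scatter, so the three groups at this place now form a complete set of pairs and none can be ranked above another. Away from this position, hydrogen in place of methoxy on the phenyl group gives a 1.2-fold higher number from compound 1 to compound 4 (0.07 log units; within the scatter), which is also within the scatter and gives a first direct reading that this second site tolerates the exchange when naphthalen-2-yl is present.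

No measurement offers a reason for the closeness of these numbers. Going by these compounds, what remains open is whether the position would keep its numbers with something quite unlike these aromatic groups, such as a small methyl, a morpholine or other amine, or a carboxylic acid, and whether the phenyl group would do the same with a larger substituent, such as a longer alkoxy chain.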